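Removing two methoxy groups from a triazole-based compound: the paw edema read-out

This account rests on a few compounds, and the source may have more. Where it says the series, first, only, none or still open, it means among the compounds named here.

Measured compounds:
- compound 1, `COc1ccc(-c2nnc(SCC(=O)c3ccccc3)n2-c2ccccc2)cc1OC`: 65%
- compound 2, `C=CCn1c(SCC(=O)c2ccccc2)nnc1-c1ccc(OC)c(OC)c1`: 72%
- compound 3, `COc1ccc(-c2nnc(SC/C(=N/O)c3ccccc3)n2-c2ccccc2)cc1OC`: 81%

Compound 1 was tested in a functional assay on the whole organism (strain albino) for inhibition, with Rattus norvegicus as the target, read by paw edema, with a stated time of 4 h, at a dose of 0.28 mmol/kg by the oral route (on this read-out higher numbers stand for more inhibition at the one dose given (going by the name of the read-out) and lower numbers for less inhibition), and gave 65%, the lowest of the three numbers. Its nearest neighbour is compound 2, where the step of a number 7 percentage points higher from compound 1 to compound 2 (within the scatter) stays within the scatter; the furthest is compound 3, where the step of a number 16 percentage points higher from compound 1 to compound 3 (beyond the scatter) is beyond it, a modest gain.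

Compound 4, `O=C(CSc1nnc(-c2ccccc2)n1-c1ccccc1)c1ccccc1`, is not yet measured. It differs from compound 1 only in one place: phenyl in place of 3,4-dimethoxyphenyl on an aromatic carbon. Neither measured step touches this group: the step to compound 2 alters the substituent on the aromatic nitrogen, and the step to compound 3 alters the chain beyond the sulfur. For the measured compounds named here, no measured step therefore bears on this change, and the data give no ground for a step beyond the scatter in either direction in this assay.

Compound 4 is therefore expected to give about 58%, within 40% to 76%, which means an expected step of a number 7 percentage points lower from compound 1 to compound 4 (within the scatter).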

Compound 4, a percentage reported as inhibition, in the whole organism at one dose (the size of the read-out at that dose, not a potency): 68%
Compound 4: the middle estimate sits 10 percentage points below what was measured; low and high end bracket the measured number.
By their numbers in this assay, from the lowest: compounds 1, 4, 2 and 3 (each within the scatter of the next, the first and the last beyond it).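

In this assay, for the compounds shown here, all the earlier compounds carried 3,4-dimethoxyphenyl on this aromatic carbon, and the change to phenyl gives a number 3 percentage points higher from compound 1 to compound 4 (within the scatter). Both methoxy groups, and with them the two hydrogen-bond acceptors counted for the leaving group, can therefore go without the read-out at this one dose moving outside the scatter, at least with the phenyl on the ring nitrogen and the chain of compound 1 in place. Nothing measured here speaks to the reason for this result.

The compounds shown leave open whether a single methoxy group, an amine or a carboxylic acid on this phenyl would give a different reading. They also leave open whether the same change holds alongside the allyl group of compound 2 or the altered chain of compound 3.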